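The source may report more compounds than this note shows. Statements on the series, on what has been measured and on what is new or still open speak of the compounds shown alone.

Measured so far in a functional assay on PC-3 cells (Homo sapiens) for cytotoxicity, read by MTT assay, with a stated time of 72 h; on this read-out lower numbers stand for stronger inhibition of growth and higher numbers for weaker inhibition of growth:
compound 1 `[SeH]c1nc2ccccc2s1` — > 50000 nM
compound 2 `C[Se]c1nc2ccccc2s1` — > 100000 nM
compound 3 `N#CSc1nc2ccccc2s1` — not yet measured

Compound 1 gives > 50000 nM in this assay, which is a limit of the assay. Compound 2 stands at > 100000 nM, likewise a limit and not a number. The step that the two limits leave unreadable from compound 1 to compound 2 rests on the limit of > 50000 nM in this assay, at which 1 of the 2 values shown sits, and (the limit of > 100000 nM in this assay, at which 1 of the 2 values shown sits), so its size cannot be read. Compound 3 differs from compound 2 by a group of 3 heavy atoms (1 carbon, 1 nitrogen, 1 sulfur; no ring) in place of a group of 2 heavy atoms (1 carbon, 1 selenium; no ring), on an aromatic carbon. No readable step bears on this change, so nothing indicates a move beyond the scatter. Compound 3 is expected to give 100000 nM (range 30000 nM to 300000 nM). The expected step is a number no higher from compound 2 to compound 3 (the limit leaves the size open), most likely again only a limit.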

Compound 3, concentration for total growth inhibition: 66300 nM
For compound 3 the middle estimate is 1.5-fold (0.18 log units) above the measured one; low and high end bracket the measured number.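

In this assay, compound 3, with the cyanosulfanyl group on the aromatic carbon, is the first compound shown to give a number and not a limit, 66300 nM. The change gives an at least 1.5-fold lower number from compound 2 to compound 3 (0.17 log units; that floor lies within the scatter), so it is not shown to move the read-out beyond the scatter. The steps from compound 1 to compound 2 and to compound 3 cannot be read.

Open, as far as these compounds go, is how an amine or a longer alkyl chain on this aromatic carbon would read. Also open, from the compounds shown here alone, is whether any group here gives a clear step.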